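A few compounds are considered here, and "the series" means these few. Any claim that something is new, unique, unknown or untested is made for them only; others in the source may bear on it.

Compound 1 `Cc1nn(C)c(C)c1-c1ccc(-c2nnc(N(C)Cc3ccc4nccn4c3)o2)c(Cl)c1` and compound 2 `Cc1cc(-c2c(C)nn(C)c2C)ccc1-c1nnc(N(C)Cc2ccc3nccn3c2)o1` share one core and differ in a single group. In an assay on COS-7 cells for inhibition of tyrosine-protein kinase receptor UFO (Homo sapiens), read by ELISA, with a stated time of 1 h (on this read-out lower numbers stand for stronger inhibition and higher numbers for weaker inhibition), compound 1 gives 794 nM, and in this assay compound 2 gives 398 nM. The step of a 2.0-fold lower number from compound 1 to compound 2 (0.30 log units; within the scatter) is within the scatter, so compound 2 stands on the lower of the two numbers but without a real order between them. Compound 3 `Cc1cc(-c2c(C)nn(C)c2C)ccc1-c1nnc(N(C)Cc2ccc3ncc(-c4cnn(CCN(C)C)c4)n3c2)o1` carries 1-(2-(dimethylamino)ethyl)-1H-pyrazol-4-yl in place of hydrogen on an aromatic carbon. Among the measured compounds shown here, no measured step concerns this part of the molecule: the only measured step, a 2.0-fold lower number from compound 1 to compound 2 (0.30 log units; within the scatter), involves a change elsewhere and gives no guide to the added group. With nothing measured pointing in either direction, for compound 3 the expected step is a 1.3-fold lower number from compound 2 to compound 3 (0.12 log units; within the scatter), with a broad range on both sides. The estimate for compound 3 in this assay is 300 nM, expected to fall between 60 nM and 1500 nM.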

Compound 3, half-maximal inhibitory concentration: 126 nM
Beside the measured number, compound 3's estimate is 2.4-fold (0.38 log units) above it; the measured number falls inside the stated range.
By their numbers in this assay, from the lowest: compound 3; then compounds 2 and 1 (each within the scatter of the next).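

This position, an aromatic carbon of the five-membered aromatic ring with 2 nitrogen, accepts a large substituent: in this assay, 1-(2-(dimethylamino)ethyl)-1H-pyrazol-4-yl in place of hydrogen gives a 3.2-fold lower number from compound 2 to compound 3 (0.50 log units; beyond the scatter). Among the compounds shown here, this modest step is the first to lie beyond the scatter, so a group of 10 heavy atoms here costs nothing on this read-out and lowers the number. Nothing measured on these compounds explains the step.

From the compounds shown here alone, it remains open whether the pyrazole ring alone accounts for the step or whether the dimethylamino group contributes to it. A plain 1-methyl-1H-pyrazol-4-yl group, or a morpholine in place of the dimethylamino group, would help separate the two parts.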